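From 3-bromophenyl to 5-bromo-2-methoxyphenyl on a shared core

The source may report more compounds than this note shows. Statements on the series, on what has been measured and on what is new or still open speak of the compounds shown alone.

Measured so far in a functional assay on MCF7 cells (Homo sapiens) for cytotoxicity, read by MTT assay, with a stated time of 96 h; on this read-out lower numbers stand for stronger inhibition and higher numbers for weaker inhibition
Compound 1 `COc1cc(C(=O)c2cn(-c3cccc([N+](=O)[O-])c3)cc2-c2ccccc2)cc(OC)c1OC` gives 550 nM
Compound 2 `COc1cc(C(=O)c2cn(-c3ccccc3)cc2-c2ccccc2Cl)cc(OC)c1OC` gives 76 nM
Compound 3 `COc1cc(C(=O)c2cn(-c3ccccc3)cc2-c2cccc(Br)c2)cc(OC)c1OC` gives 950 nM

In this assay compound 3 stands at 950 nM and lies within the scatter of compound 1 at 550 nM on the same read-out. The gap to compound 2 is large, with a 13-fold higher number from compound 2 to compound 3 (1.10 log units; beyond the scatter) on the record.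

Compound 4 `COc1ccc(Br)cc1-c1cn(-c2ccccc2)cc1C(=O)c1cc(OC)c(OC)c(OC)c1` is compound 3 with one change, methoxy in place of hydrogen on an aromatic carbon as counted, which is methoxy in place of hydrogen on an aromatic carbon, turning 3-bromophenyl into 5-bromo-2-methoxyphenyl. Among the measured compounds shown here, no measured step adds this methoxy. The nearest evidence is a 13-fold higher number from compound 2 to compound 3 (1.10 log units; beyond the scatter) as a loose guide, since that step alters both the halogen and its place. Compound 2 at 76 nM also holds its substituent ortho to a large group, and compound 4 would gain one there, so a move toward compound 2 is expected, though a smaller one. The expected change is a 4.3-fold lower number from compound 3 to compound 4 (0.64 log units; beyond the scatter) by this estimate. Compound 4 is expected at 220 nM within an estimated range from 45 nM to 950 nM until it is measured.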

Compound 4, half-maximal inhibitory concentration: 2200 nM
The estimate for compound 4 lay 10-fold (1.00 log units) below the measured number; measured number outside the range, above it.
By their numbers in this assay, from the lowest: compound 2; then compounds 1 and 3 (each within the scatter of the next); then compound 4.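

In this assay, methoxy in place of hydrogen on the aromatic carbon ortho to a large group and para to a bromo group gives a 2.3-fold higher number from compound 3 to compound 4 (0.36 log units; beyond the scatter), a modest move toward weaker inhibition. Set against the 2-chlorophenyl of compound 2, the 5-bromo-2-methoxyphenyl gives a 29-fold higher number from compound 2 to compound 4 (1.46 log units; beyond the scatter), so carrying a 2-substituent on this phenyl does not on its own restore the low number of compound 2. Nothing on hand explains either step.

The compounds shown leave open whether methoxy would give a similar step on the 2-chlorophenyl of compound 2 or on an unsubstituted phenyl, where the bromo group is absent. They also leave open how an amine, a hydroxyl or a longer ether chain would behave on this same aromatic carbon.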